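The source may report more compounds than this note shows. Statements on the series, on what has been measured and on what is new or still open speak of the compounds shown alone.

In a functional assay on HEL cells (Homo sapiens), read by microscopy (a higher number here means that more compound is tolerated, a lower number that less compound is tolerated), compound 1 `CCCCCCCC#Cc1cc2cn(COCCO)c(=O)nc2o1` gives 200000 nM. Compound 2 `CCCCCCCCC#Cc1cc2cn(COCCO)c(=O)nc2o1` gives only a limit of the assay, >= 20000 nM, not a number. The step that the limit leaves unreadable from compound 1 to compound 2 is thus left unreadable by the limit of >= 20000 nM in this assay, at which 1 of the 3 values shown sits; the change is methyl in place of hydrogen on a saturated chain carbon, seven bonds along the chain from a triple-bonded carbon. Compound 3 `CCCCCc1cc2cn(COCCO)c(=O)nc2o1` carries a second core; the difference between the two cores is not broken down here. In this assay compound 3 gives only a limit, > 400000 nM, which is the limit of > 400000 nM in this assay, at which 1 of the 3 values shown sits. Compound 4 `CCCCCCc1cc2cn(COCCO)c(=O)nc2o1` is not yet measured; it differs from compound 3 by methyl in place of hydrogen on a saturated chain carbon, five bonds along the chain from an aromatic carbon, the same kind of change as from compound 1 to compound 2, though the place differs: five bonds along the chain from an aromatic carbon rather than seven bonds along the chain from a triple-bonded carbon. The expected step of an at least 1.3-fold lower number from compound 3 to compound 4 (0.12 log units; that floor lies within the scatter) is set small, since a step that the limit leaves unreadable from compound 1 to compound 2 is itself unreadable because of the limit of >= 20000 nM in this assay, at which 1 of the 3 values shown sits. Compound 4 is expected at 300000 nM, between 120000 nM and 400000 nM.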

Compound 4, minimum cytotoxic concentration: >= 400000 nM
Compound 4 gave a limit, no number; the forecaster's own chance of this, stated with the estimate: 55%; middle value at least 1.3-fold (0.12 log units) away from the limit.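

Going by these compounds alone, compound 3 and compound 4 both give only limits in this assay, and no step between them can be read. The compounds shown leave open how far methyl in place of hydrogen on a saturated chain carbon shifts the minimum cytotoxic concentration.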